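The source may hold more compounds than are shown below. What is called first, only, known or untested is meant among the compounds shown, and "the series" means these compounds.

In an ADME assay on BHK-21 cells (Mesocricetus auratus) for cytotoxicity, read by MTT assay, with a stated time of 96 h (on this read-out higher numbers stand for lower toxicity in this test and lower numbers for higher toxicity in this test), compound 1 `CN(C)CCCN(/N=N/c1cc(F)ccc1F)c1ccccc1` gives 25000 nM.
In this assay compound 3 `CN(C)CCCN(/N=N/c1cc(F)ccc1F)c1cccc(C(F)(F)F)c1` gives 54000 nM.
In this assay compound 2 `Cc1c(/N=N/c2cccc(C(F)(F)F)c2)ccc(NC[C@@H]2CCCN3CCCC[C@H]23)c1C` gives >= 100000 nM, which is a limit of the assay and not a number.

Compound 3 and compound 1 differ in one place only: hydrogen in place of trifluoromethyl on an aromatic carbon. That change produced a 2.2-fold lower number from compound 3 to compound 1 (0.33 log units; beyond the scatter), so among these three compounds the one lacking the trifluoromethyl group showed the higher toxicity in this test.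

Compound 4 `Cc1c(/N=N/c2ccccc2)ccc(NC[C@@H]2CCCN3CCCC[C@H]23)c1C` has not yet been measured. It arises from compound 2 by the same change, (hydrogen in place of trifluoromethyl on an aromatic carbon), and the place of the change is described in the same words for both pairs, so it counts as the same change. How the core of compound 2 differs from the core of compound 3 is not broken down here. Compound 2 itself offers no exact starting number, only (the limit of >= 100000 nM in this assay, at which 1 of the 3 values shown sits); any expectation for compound 4 therefore rests on thin ground.

Because the measured pair showed a 2.2-fold lower number from compound 3 to compound 1 (0.33 log units; beyond the scatter), the step is expected to be an at least 1.6-fold lower number from compound 2 to compound 4 (0.22 log units; that floor lies within the scatter), reaching downward from a limit rather than from a fixed value. Compound 4 is accordingly estimated at 60000 nM in this assay, with a plausible range from 25000 nM to 150000 nM, and a real chance that only a limit is reported again.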

Compound 4, half-maximal cytotoxic concentration: 47000 nM
For compound 4 the middle estimate is 1.3-fold (0.11 log units) above the measured one; low and high end bracket the measured number.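

In this assay, putting hydrogen in place of trifluoromethyl gave an at least 2.1-fold lower number from compound 2 to compound 4 (0.32 log units; beyond the scatter), so on this second core too the compound without trifluoromethyl has the lower number, which stands for higher toxicity in this test. Two pairs show that the direction of the step carried over from one core to the other, but they do not make a rule for the whole series, and the sizes of the two steps can be compared only so far: the same change on two cores in this assay, a 2.2-fold lower number (0.33 log units; beyond the scatter) from compound 3 to compound 1 and an at least 2.1-fold lower number (0.32 log units; beyond the scatter) from compound 2 to compound 4; the limit leaves it open whether they differ. The step from compound 2 has no exact size, only a smallest possible one, since the value of compound 2 is a limit of the assay and not a number: the limit of >= 100000 nM in this assay, at which 1 of the 4 values shown sits.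

The compounds shown compare only trifluoromethyl with hydrogen, so they leave open how a chlorine atom, a methoxy group or a nitrile on the same aromatic carbon would read in this assay. They also leave open whether the same step would appear on a core carrying a carboxylic acid, or a longer chain in place of the amine-bearing side chains seen here.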